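From methyl to allyl on compound 1

A few compounds are considered here, and "the series" means these few. Any claim that something is new, unique, unknown or untested is made for them only; others in the source may bear on it.

Two compounds have been measured so far in a functional assay on the whole organism with Cavia porcellus as the target (a higher number here means that more compound is needed for the effect, a lower number that less compound is needed), so far:
- Compound 1 `COc1cc(C(=O)NS(=O)(=O)c2ccccc2C)ccc1Cc1cn(C)c2ccc(C(=O)NCC3CCCC3)cc12` gives 19.2 umol/kg
- Compound 2 `COc1cc(C(=O)NS(=O)(=O)c2ccccc2C)ccc1Cc1cn(C)c2ccc(C(=O)NCC(C)C)cc12` gives > 30 umol/kg as a limit of the assay, not a number

Going by the values given here, compound 1 therefore holds the only true number. Compound 3 `C=CCn1cc(Cc2ccc(C(=O)NS(=O)(=O)c3ccccc3C)cc2OC)c2cc(C(=O)NCC3CCCC3)ccc21` differs from compound 1 by vinyl in place of hydrogen on a saturated chain carbon bound to an aromatic nitrogen in one change, vinyl in place of hydrogen on a saturated chain carbon bound to an aromatic nitrogen. Among the compounds with values here, the only measured step of an at least 1.5-fold higher number from compound 1 to compound 2 (0.19 log units; that floor lies within the scatter) changes a different place, so no step beyond the scatter is expected in this assay in either direction. In numbers, the expected change is a 1.1-fold higher number from compound 1 to compound 3 (0.06 log units; within the scatter) and no more. Compound 3 is estimated at 22 umol/kg with an expected range of 9 umol/kg to 50 umol/kg.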

Compound 3, dose for half-maximal effect: 9.9 umol/kg
Estimate against measurement, compound 3: 2.2-fold (0.35 log units) above, within the range that was stated.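

In this assay, methyl to allyl, the first change shown at this position, gives a 1.9-fold lower number from compound 1 to compound 3 (0.29 log units; within the scatter). The position therefore accepts allyl without a shift beyond the usual scatter, and compound 3 yields a true number. Compound 2, which changes a different place, remains a limit and not a number: the limit of > 30 umol/kg in this assay, at which 1 of the 3 values shown sits.

Going by these compounds, whether a longer chain, a benzyl group or an amine on the aromatic nitrogen would move the number beyond the scatter stays open. So does whether the double bond of allyl matters, which a saturated propyl group would test.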